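Para-substituted aryl ketone on the shared core

The compounds below may be only part of what the source reports. "The series", "measured", "known", "first", "only" and "open" are said of these compounds alone.

Measured compounds in a functional assay on PC-3 cells (Homo sapiens) for cytotoxicity, read by MTT assay, with a stated time of 48 h; on this read-out lower numbers stand for stronger inhibition and higher numbers for weaker inhibition:
compound 1 `COc1cc(-c2nnc3n2NC(c2ccco2)C(C(=O)c2ccccc2C)S3)cc(OC)c1OC` gives 88400 nM
compound 2 `COc1cc(-c2nnc3n2NC(c2ccco2)C(C(=O)c2ccccc2F)S3)cc(OC)c1OC` gives > 100000 nM
compound 3 `COc1cc(-c2nnc3n2NC(c2ccco2)C(C(=O)c2ccc(Cl)cc2)S3)cc(OC)c1OC` gives 67800 nM

Compound 2 stands at a limit of this assay, not at a number: the limit of > 100000 nM in this assay, at which 1 of the 3 values shown sits. Compound 4 `COc1cc(-c2nnc3n2NC(c2ccco2)C(C(=O)c2ccc(C(F)(F)F)cc2)S3)cc(OC)c1OC` differs from compound 2 at one place, (4-(trifluoromethyl)phenyl in place of 2-fluorophenyl on a carbonyl carbon). The closest measured step exchanges the same 2-fluorophenyl for another para-substituted ring: an at least 1.4-fold lower number from compound 2 to compound 3 (0.16 log units; that floor lies within the scatter). The step of an at least 1.1-fold higher number from compound 1 to compound 2 (0.05 log units; that floor lies within the scatter) and the step of a 1.3-fold lower number from compound 1 to compound 3 (0.12 log units; within the scatter) also sit within the scatter, so the three measured compounds do not separate. Compound 4 is therefore expected to show no step beyond the scatter, an at least 1.1-fold lower number from compound 2 to compound 4 (0.07 log units; that floor lies within the scatter), and its value in this assay is estimated at 85000 nM, with a range from 40000 nM to 180000 nM, and a real chance that only a limit is reported again.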

Compound 4, half-maximal inhibitory concentration: 77500 nM
Estimate against measurement, compound 4: 1.1-fold (0.04 log units) above, within the range that was stated.
By their numbers in this assay, from the lowest: compounds 3, 4 and 1 (each within the scatter of the next). At a limit, above all of these: compound 2.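

Compound 2 stands at a limit of the assay, not at a number: the limit of > 100000 nM in this assay, at which 1 of the 4 values shown sits.

In this assay, 4-(trifluoromethyl)phenyl on this carbonyl carbon gives a number, with an at least 1.2-fold lower number from compound 2 to compound 4 (0.11 log units; that floor lies within the scatter), while trifluoromethyl in place of chloro on the aromatic carbon gives a 1.1-fold higher number from compound 3 to compound 4 (0.06 log units; within the scatter). The change from 2-methylphenyl gives a 1.1-fold lower number from compound 1 to compound 4 (0.06 log units; within the scatter), so the three numbers now measured do not separate.

On these data alone, it remains open whether an amine or a carboxylic acid on this aromatic ring would move the value beyond the scatter.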